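The source may hold more compounds than are shown below. What is called first, only, known or untested is meant among the compounds shown, and "the series" means these compounds.

Measured compounds:
compound 1 `O=C(NCCNS(=O)(=O)c1ccc(-c2ccccc2Oc2ccc(O)c(O)c2)s1)Nc1cc(Cl)cc(Cl)c1` gives > 20000 nM in a functional assay on HeLa cells (Homo sapiens) for inhibition, read by CCK-8 assay, with a stated time of 48 h; a higher number here means a weaker inhibitor, a lower number a stronger inhibitor — this value is a limit of the assay, not a number.
compound 2 `O=S(=O)(NCCNC(=S)Nc1ccc(Cl)cc1)c1ccc(-c2ccccc2OCc2ccccc2)s1` gives 7000 nM.
compound 3 `COc1ccc(Oc2ccc(C(C)C)cc2-c2ccsc2S(=O)(=O)NCCNC(=O)Nc2cc(Cl)cc(Cl)c2)cc1OC` gives 11600 nM.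

Compound 3 holds the higher of the two numbers, and compound 2 lies nearest to it; the gap between them stays within the usual scatter, so neither can be called the stronger inhibitor. Compound 1 sits at the limit (the limit of > 20000 nM in this assay, at which 1 of the 3 values shown sits).

Compound 4 `CC(C)c1ccc(Oc2ccc(O)c(O)c2)c(-c2ccsc2S(=O)(=O)NCCNC(=O)Nc2cc(Cl)cc(Cl)c2)c1` differs from compound 3 in one place: 3,4-dihydroxyphenyl in place of 3,4-dimethoxyphenyl on an oxygen on an aromatic ring. Compound 1 also carries a 3,4-dihydroxyphenyl, and it gives only a limit, > 20000 nM. A step toward weaker inhibition from compound 3 to compound 4 is expected, a 1.6-fold higher number from compound 3 to compound 4 (0.19 log units; within the scatter), possibly beyond the scatter. Compound 4 is estimated at 18000 nM, with a range from 8000 nM to 40000 nM, and a limit rather than a number would not surprise.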

Compound 4, half-maximal inhibitory concentration: > 50000 nM
Compound 4: only a limit was reported; the forecaster's own chance of this, stated with the estimate: 45%; middle value at least 2.7-fold (0.44 log units) away from the limit.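

Going by these compounds alone, putting 3,4-dihydroxyphenyl in place of 3,4-dimethoxyphenyl on an oxygen on an aromatic ring gives, in this assay, an at least 4.3-fold higher number from compound 3 to compound 4 (0.63 log units; beyond the scatter) as the first one-place comparison at this position. Compound 4 gives a limit, not a number: the limit of > 50000 nM in this assay, at which 1 of the 4 values shown sits. Compound 1, which also carries 3,4-dihydroxyphenyl, likewise gives a limit, not a number: the limit of > 20000 nM in this assay, at which 1 of the 4 values shown sits.

The compounds shown leave open how far inhibition would lie from compound 3 with only one of the two methoxy groups replaced by a hydroxy group. They also leave open whether an amine or a carboxylic acid on this ring would retain inhibition.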